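Fluoro for methylsulfanyl on the diaryl ether aniline

The source may report more compounds than this note shows. Statements on the series, on what has been measured and on what is new or still open speak of the compounds shown alone.

Three members of the series have been measured in an in vivo ADME assay on the whole organism (strain C57BL/cAnNCrl) for metabolic stability, with Mus musculus as the target, at a dose of 10 mg/kg by the oral route; on this read-out higher numbers stand for a longer-lived compound and lower numbers for a shorter-lived compound. Compound 1 `Cc1nc2c(Oc3ccc(NC(=O)Nc4cc(C(F)(F)F)ccc4F)c4ccccc34)ccnc2[nH]c1=O` gives 6 h. Compound 2 `CSc1cc(Oc2ccnc3[nH]c(=O)cnc23)ccc1NC(=O)Nc1cc(C(C)(C)C)nn1-c1ccc(C)cc1` gives 7.9 h, the highest of the three numbers, though its separation from compound 3 and from compound 1 is within the scatter, so no ordering among them is claimed. Compound 3 `Cc1ccc(-n2nc(C(C)(C)C)cc2NC(=O)Nc2ccc(Oc3ccnc4[nH]c(=O)cnc34)cc2)cc1` gives 6.3 h in this assay.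

Compound 4 `Cc1ccc(-n2nc(C(C)(C)C)cc2NC(=O)Nc2ccc(Oc3ccnc4[nH]c(=O)cnc34)cc2F)cc1` is the next member. It differs from compound 2 by fluoro in place of methylsulfanyl on an aromatic carbon.

Within the data shown here, the one measured step that bears on this position is the removal of the same group: from compound 2 to compound 3, this assay shows a 1.3-fold lower number from compound 2 to compound 3 (0.10 log units; within the scatter). Compound 1 carries a fluoro on its other aryl ring and is not a matched pair with compound 2; it only shows that a fluoro-bearing member sits in the same band as compounds 2 and 3. Taking hydrogen and fluoro as comparable replacements at this carbon, the step from compound 2 to compound 4 in this assay is expected to be a 1.2-fold lower number from compound 2 to compound 4 (0.08 log units; within the scatter), a change not beyond the scatter.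

Compound 4 is therefore estimated at 6.5 h in this assay, within a range of 3.5 h to 12 h.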

Compound 4, half-life: 5.9 h
Compound 4: the middle estimate sits 1.1-fold (0.04 log units) above what was measured, within the range that was stated.
By their numbers in this assay, from the lowest: compounds 4, 1, 3 and 2 (each within the scatter of the next).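

In this assay, fluoro in place of methylsulfanyl on this aromatic carbon, ortho to a large group and meta to a large group, gives a 1.3-fold lower number from compound 2 to compound 4 (0.13 log units; within the scatter), so a replacement with fewer heavy atoms and no hydrogen-bond acceptor leaves the number within the scatter. Among these compounds, the matched pair that the earlier compounds lacked, fluoro against hydrogen at the same carbon, gives a 1.1-fold lower number from compound 3 to compound 4 (0.03 log units; within the scatter), and with it methylsulfanyl, hydrogen and fluoro have all been read at this carbon on one scaffold without any step beyond the scatter. Nothing available here bears on the reason these steps are so small.

Open, from the compounds shown here alone, is whether this insensitivity extends to groups of a different kind at this carbon, such as an amine, a carboxylic acid or a longer chain like ethylsulfanyl, since the three substituents read so far do not include any of these. Also open is whether the same replacement behaves alike on the core of compound 1, where no matched pair at this position is shown.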